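The source may report more compounds than this note shows. Statements on the series, on what has been measured and on what is new or still open speak of the compounds shown alone.

Compound 1 `COc1cc(OC)c(/C=C/C(=O)/C=C/c2cc3ccccc3nc2Oc2ccc(Br)cc2)c(OC)c1`: > 10000 nM
Compound 2 `COc1cc(OC)c(/C=C/C(=O)/C=C/c2cc3ccccc3nc2Oc2cccc(Cl)c2)c(OC)c1`: > 10000 nM

In a functional assay on DU-145 cells (Homo sapiens) for cytotoxicity, read by MTT assay, with a stated time of 48 h (a lower number here means a stronger inhibitor, a higher number a weaker inhibitor), compound 1 gives > 10000 nM, which is a limit of the assay and not a number. Compound 2 gives > 10000 nM, and this too is a limit. For the measured compounds named here, compound 2 therefore has no exact place on the scale, and the only other value beside it is also a limit.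

Going by the values given here, the next compound, compound 3 `COc1cc(OC)c(/C=C/C(=O)/C=C/c2cc3ccccc3nc2Oc2ccccc2C(C)C)c(OC)c1`, keeps the shared core and changes only one group: 2-isopropylphenyl in place of 3-chlorophenyl on an oxygen on an aromatic ring. The counted difference is 2-isopropylphenyl in place of 3-chlorophenyl on an oxygen on an aromatic ring.

Among the compounds with values here, only one measured step bears on this change, and it concerns the same place on the molecule: a step that the two limits leave unreadable from compound 1 to compound 2. Its size cannot be read, so it offers no direction for the new change. The evidence so far is the limit of > 10000 nM in this assay, at which 2 of the 2 values shown sit. Compound 3 is therefore expected to stay in the same region, quite possibly as another limit, with no clear change expected. The estimated step is a step that the limit leaves unreadable from compound 2 to compound 3. In this assay the estimated value for compound 3 is 12000 nM, with an expected range from 3000 nM to 25000 nM.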

Compound 3, half-maximal inhibitory concentration: > 10000 nM
Compound 3: a limit, no number; the forecaster's own chance of this, stated with the estimate: 75%; the middle value does not contradict the limit.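

In this assay, for the compounds shown here, compound 3 gives > 10000 nM, again a limit of the assay and not a number, so no step among compound 1, compound 2 and compound 3 can be read. The compounds shown leave open how much the group on that oxygen matters, and whether any such group would give a measurable value. The record so far stands as follows: the limit of > 10000 nM in this assay, at which 3 of the 3 values shown sit.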